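The source may hold more compounds than are shown below. What is called first, only, known or untested is meant among the compounds shown, and "the series" means these compounds.

Compound 2 `O=C(O)CCSC(=S)NCc1cccnc1` gives 9320 nM in a functional assay on MDA-MB-468 cells (Homo sapiens) for cytotoxicity, read by resazurin assay, with a stated time of 72 h (a lower number here means a stronger inhibitor, a higher number a weaker inhibitor), and stands beside compound 1 `OCCCSC(=S)NCc1cccnc1`, which gives 6610 nM; the two numbers lie within the scatter of each other. Compound 3 `S=C(NCc1cccnc1)SCCc1nnn[nH]1` differs from compound 2 by 1H-tetrazol-5-yl in place of carboxy on a saturated chain carbon, two bonds along the chain from a sulfur. Among the measured compounds shown here, only one measured step touches this place: a 1.4-fold higher number from compound 1 to compound 2 (0.15 log units; within the scatter). That exchange at the same carbon left the number within the scatter, so no larger move is foreseen. Compound 3 is expected to show a 1.0-fold lower number from compound 2 to compound 3 (0.02 log units; within the scatter), none beyond the scatter. The estimate for compound 3 is 9000 nM, ranging from 3000 nM to 27000 nM.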

Compound 3, half-maximal inhibitory concentration: > 100000 nM
Compound 3: a limit, no number; the forecaster's own chance of this, stated with the estimate: 10%; middle value at least 11-fold (1.04 log units) from the limit.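

The position tolerates less than the earlier pair suggested: exchanging hydroxymethyl for carboxy gave only a 1.4-fold higher number from compound 1 to compound 2 (0.15 log units; within the scatter), yet 1H-tetrazol-5-yl on the same saturated chain carbon gives an at least 10-fold higher number from compound 2 to compound 3 (1.03 log units; beyond the scatter) and an at least 15-fold higher number from compound 1 to compound 3 (1.17 log units; beyond the scatter). So this place does respond to what it carries, and a five-membered aromatic ring here takes the cytotoxicity of the series out of reach of the assay. The reading for compound 3 is a limit, not a number: the limit of > 100000 nM in this assay, at which 1 of the 3 values shown sits.

The compounds shown leave open whether an amine or a longer chain ending in a carboxylic acid at this carbon would stay near compound 1 and compound 2 or move as far as compound 3.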